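Mirror-Image Pair in a TRPM8 Agonist Series

The source may report more compounds than this note shows. Statements on the series, on what has been measured and on what is new or still open speak of the compounds shown alone.

Compound 1 `C=CCc1cc(OC)c(O[C@H](C)[C@@H](OCC)c2ccc(O)c(OC)c2)c(OC)c1`: 1150 nM
Compound 2 `C=CCc1cc(OC)c(OC(C)C(OCCOCCCC)c2ccc(O)c(OC)c2)c(OC)c1`: 153 nM
Compound 3 `C=CCc1cc(OC)c(OC(C)C(OC)c2ccc(O)c(OC)c2)c(OC)c1`: 3450 nM

In an assay on HEK293 cells for agonist activity at transient receptor potential cation channel subfamily M member 8 (Homo sapiens), read by fluorescence and calcium flux, with a stated time of 5 min (a higher number here means that more compound is needed for the effect, a lower number that less compound is needed), compound 1 stands second highest of the three numbers, beyond the scatter from both compound 2 and compound 3. Going by the values given here, the only one-place step recorded, a 23-fold higher number from compound 2 to compound 3 (1.35 log units; beyond the scatter), concerns a chain substituent and not configuration. Compound 4 `C=CCc1cc(OC)c(O[C@@H](C)[C@H](OCC)c2ccc(O)c(OC)c2)c(OC)c1` differs from compound 1 only as follows: the two compounds have the same atoms and bonds and differ only in configuration as drawn: 2 of 2 stereo elements differ (all stereocentres are inverted: mirror images); a stereocentre at a saturated chain carbon is drawn R in compound 1 and S in compound 4; a stereocentre at a saturated chain carbon is drawn S in compound 1 and R in compound 4. Among the compounds with values here, no measured pair bears on an inversion of both stereocentres, so the direction of the change in this assay cannot be read from the data; the estimate is therefore wide. Compound 4 is expected near 2000 nM, between 400 nM and 10000 nM, meaning an expected step of a 1.7-fold higher number from compound 1 to compound 4 (0.24 log units; within the scatter).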

Compound 4, half-maximal effective concentration: 1130 nM
Beside the measured number, compound 4's estimate is 1.8-fold (0.25 log units) above it, and the stated range covers the measured number.
By their numbers in this assay, from the lowest: compound 2; then compounds 4 and 1 (each within the scatter of the next); then compound 3.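

Inverting both stereocentres gives a 1.0-fold lower number from compound 1 to compound 4 (0.01 log units; within the scatter) in this assay, so this assay does not tell the two mirror images apart. The earlier compounds shown here showed only how strongly the number responds to a chain substituent; this pair shows that, at these two stereocentres, full inversion leaves the number within the scatter. The comparison concerns configuration alone: the fact that compounds 1 and 4 differ only in the configuration as drawn.

The compounds shown leave open what inverting just one of the two stereocentres does. They also leave open whether the same holds with an amine or a carboxylic acid on a saturated chain carbon.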